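Compound 4: methoxy in place of methyl, cytotoxicity expected

The compounds below may be only part of what the source reports. "The series", "measured", "known", "first", "only" and "open" are said of these compounds alone.

Measured in a functional assay on C6 cells (Rattus norvegicus) for cytotoxicity, read by MTT assay, with a stated time of 24 h, tested at 25 ug/mL; on this read-out lower numbers stand for a stronger effect and higher numbers for a weaker effect at the one concentration tested:
compound 1 `O=C(CSc1ncccn1)N/N=c1/scc(-c2ccc(Br)cc2)n1-c1ccccc1` gives 72.3%
compound 2 `O=C(CSc1ncccn1)N/N=c1/scc(-c2ccc(Cl)cc2)n1-c1ccccc1` gives 91.1%
compound 3 `Cc1ccc(-c2cs/c(=N/NC(=O)CSc3ncccn3)n2-c2ccccc2)cc1` gives 82.7%

Compound 3 stands second highest of the three numbers: its gap to compound 2 is within the scatter, while the step of a number 10.4 percentage points higher from compound 1 to compound 3 (beyond the scatter) lies beyond it. Compound 4 `COc1ccc(-c2cs/c(=N/NC(=O)CSc3ncccn3)n2-c2ccccc2)cc1` differs from compound 3 by methoxy in place of methyl on an aromatic carbon. Among the compounds with values here, no measured step exchanges methyl for methoxy, so none bears on it directly. What exists are the three steps at the same place, a number 18.8 percentage points higher from compound 1 to compound 2 (beyond the scatter), a number 10.4 percentage points higher from compound 1 to compound 3 (beyond the scatter) and a number 8.4 percentage points lower from compound 2 to compound 3 (within the scatter), which show that changing the group on this carbon moves the number by modest amounts at most. A step of similar size in either direction, or none beyond the scatter, is therefore expected in this assay. For compound 4 the estimate is 85%, with a range from 66% to 100%. This means an expected step of a number 2.3 percentage points higher from compound 3 to compound 4 (within the scatter).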

Compound 4, a percentage reported as activity, at one concentration (the size of the read-out at that concentration, not a potency): 74%
The estimate for compound 4 lay 11 percentage points above the measured number, within the range that was stated.
By their numbers in this assay, from the lowest: compounds 1, 4, 3 and 2 (each within the scatter of the next, the first and the last beyond it).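

Within the data shown here, with 4-methoxyphenyl, an oxygen-bearing group enters this aromatic carbon for the first time, and in this assay the step of a number 8.7 percentage points lower from compound 3 to compound 4 (within the scatter) does not separate methoxy from methyl. The step of a number 1.7 percentage points higher from compound 1 to compound 4 (within the scatter) places methoxy alongside bromo, while the step of a number 17.1 percentage points lower from compound 2 to compound 4 (beyond the scatter) separates methoxy from chloro, so the change of group at this carbon still gives only modest steps. No supporting data bear on why these groups fall as they do.

Open, from the compounds shown here alone, is how an amine, a carboxylic acid or a longer chain in place of methoxy on this carbon would read in this assay. Also open, going by these compounds, is whether these small steps would hold at other concentrations or with changes elsewhere on the shared core.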